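A few compounds are considered here, and "the series" means these few. Any claim that something is new, unique, unknown or untested is made for them only; others in the source may bear on it.

Measured in a physicochemical assay for solubility, read by chemiluminescence, measured as kinetic solubility; on this read-out higher numbers stand for higher solubility and lower numbers for lower solubility:
- Compound 1 `COc1cccc2c1c(NS(=O)(=O)c1ccc(Cl)s1)nn2Cc1cccc(CNC(=O)C2COC2)c1`: >= 173 ug/mL, a limit
- Compound 2 `COc1cccc2c1c(NS(=O)(=O)c1ccc(Cl)s1)nn2Cc1cccc(CNC(=O)C(C)(C)N)c1`: >= 180 ug/mL, a limit
- Compound 3 `COc1cccc2c1c(NS(=O)(=O)c1ccc(Cl)s1)nn2Cc1cccc(CNC(=O)[C@@H]2CCCCN2)c1`: >= 220 ug/mL, a limit

Compound 3 stands at >= 220 ug/mL, which is a limit. The two other values are limits too.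

Next is compound 4 `COc1cccc2c1c(NS(=O)(=O)c1ccc(Cl)s1)nn2Cc1cccc(CNC2COC2)c1`: oxetan-3-yl in place of (piperidin-2-yl)carbonyl on an amine nitrogen. In words, oxetan-3-yl replaces (piperidin-2-yl)carbonyl on an amine nitrogen. The measured steps that bear on this are a step that the two limits leave unreadable from compound 1 to compound 3, a step that the two limits leave unreadable from compound 2 to compound 3 and a step that the two limits leave unreadable from compound 1 to compound 2. All three changes sit on a carbonyl carbon, not on an amine nitrogen, and none has a readable size. No step beyond the scatter is therefore expected in this assay, in either direction. The expected change is an at least 1.1-fold lower number from compound 3 to compound 4 (0.06 log units; that floor lies within the scatter). The estimate for compound 4 is 190 ug/mL, with an expected range of 100 ug/mL to 260 ug/mL.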

Compound 4, solubility: 122 ug/mL
For compound 4 the middle estimate is 1.6-fold (0.19 log units) above the measured one, and the stated range covers the measured number.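

Among the compounds shown here, compound 4 gives the first reading at this position in this assay that is not a limit, with oxetan-3-yl on the amine nitrogen and no carbonyl. The steps are an at least 1.8-fold lower number from compound 3 to compound 4 (0.25 log units; that floor lies within the scatter), an at least 1.4-fold lower number from compound 2 to compound 4 (0.16 log units; that floor lies within the scatter) and an at least 1.4-fold lower number from compound 1 to compound 4 (0.15 log units; that floor lies within the scatter). Compound 1 and compound 4 both carry oxetan-3-yl, so the last step isolates the loss of the carbonyl, while the steps among compound 1, compound 2 and compound 3 cannot be read.

From the compounds shown here alone, the full size of each step to compound 4 remains open. Also open, going by these compounds, is how piperidin-2-yl without its carbonyl, a carboxylic acid or a longer chain on this amine nitrogen would read.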